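Difluoromethyl for methyl on the isoxazole of compound 1

The source may report more compounds than this note shows. Statements on the series, on what has been measured and on what is new or still open speak of the compounds shown alone.

Measured compounds:
compound 1, `Cc1noc(C)c1[C@@H]1C[C@@](C)(c2ccc(F)cc2F)N=C(N)S1`: 72%
compound 2, `CCc1noc(C)c1[C@@H]1C[C@@](C)(c2ccc(F)cc2F)N=C(N)S1`: 41%
compound 3, `Cc1onc(-c2ccc(F)cc2)c1[C@@H]1C[C@@](C)(c2ccc(F)cc2F)N=C(N)S1`: 23%

In an ADME assay on microsomes from liver (Mus musculus) for metabolic stability, with a stated time of 10 min, tested at 0.5 uM (on this read-out lower numbers stand for a less stable compound and higher numbers for a more stable compound), compound 1 stands highest of the three. Compound 2 lies closer to it, the step being a number 31 percentage points lower from compound 1 to compound 2 (beyond the scatter), and compound 3 lies furthest, with a number 49 percentage points lower from compound 1 to compound 3 (beyond the scatter). Between the two lower compounds the step is a number 18 percentage points lower from compound 2 to compound 3 (beyond the scatter).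

The unmeasured compound 4, `Cc1noc(C(F)F)c1[C@@H]1C[C@@](C)(c2ccc(F)cc2F)N=C(N)S1`, differs from compound 1 in one place: difluoromethyl in place of methyl on an aromatic carbon. The measured steps from compound 1 both enlarge a group on the five-membered ring and both lowered the number beyond the scatter, the larger group giving the larger drop. For the measured compounds named here, they do not, however, touch the methyl that is exchanged here, and no step in the set replaces a methyl by difluoromethyl. Going by the values given here, the change to compound 4 is a small addition in heavy atoms compared with the step to compound 3, so he expects a step in this assay no larger than the one to compound 2, most likely a small decrease or none beyond the scatter.

For compound 4 he therefore estimates 62%, within 42% to 80%, which means an expected step of a number 10 percentage points lower from compound 1 to compound 4 (within the scatter).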

Compound 4, percent of the compound remaining: 59%
The estimate for compound 4 lay 3 percentage points above the measured number; low and high end bracket the measured number.
By their numbers in this assay, from the lowest: compound 3; then compound 2; then compound 4; then compound 1.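

In this assay, for the compounds shown here, the result shows for the first time that the methyl next to the ring oxygen is itself sensitive to change: difluoromethyl there gives a number 13 percentage points lower from compound 1 to compound 4 (beyond the scatter). The earlier steps shown here, a number 31 percentage points lower from compound 1 to compound 2 (beyond the scatter) and a number 49 percentage points lower from compound 1 to compound 3 (beyond the scatter), both altered the other methyl, two ring bonds away, so the three steps together show that compound 1 keeps the highest number in this assay whichever of the two ring positions is changed, while the step at this position is classed as modest and those two as large. Nothing measured here explains the lower number for compound 4, and no separate measurement bears on it.

From the compounds shown here alone, it remains open whether the drop follows from the two fluorines or from any enlargement at this carbon, which trifluoromethyl, hydroxymethyl or a plain ethyl on the same ring atom would help to separate. Also open, going by these compounds, is what difluoromethyl would do on the ring atom that bears the other methyl, where compound 2 and compound 3 carry their changes.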